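Replacing fluoro with dimethylamino in compound 3

The compounds below may be only part of what the source reports. "The series", "measured", "known", "first", "only" and "open" are said of these compounds alone.

In a functional assay on PC3-TxR cells (Homo sapiens) for antiproliferative activity, read by sulforhodamine B assay, with a stated time of 96 h (on this read-out higher numbers stand for weaker inhibition and lower numbers for stronger inhibition), compound 1 (`CN(C)c1ccc2c(c1)OC(N)=C(C#N)C2c1cccc2c(F)cccc12`) gives 190 nM and compound 2 (`COc1ccc(C2C(C#N)=C(N)Oc3cc(N(C)C)ccc32)c2ccccc12`) gives 530 nM. Compound 3 (`CN(C)c1ccc2c(c1)OC(N)=C(C#N)C2c1ccc(F)c2ccccc12`) gives 290 nM, within the scatter of both. Compound 4 (`CN(C)c1ccc2c(c1)OC(N)=C(C#N)C2c1ccc(N(C)C)c2ccccc12`) carries dimethylamino in place of fluoro on an aromatic carbon, para to a large group: dimethylamino in place of fluoro on an aromatic carbon. For the measured compounds named here, the only measured step at this carbon is a 1.8-fold lower number from compound 2 to compound 3 (0.26 log units; within the scatter), where fluoro replaced methoxy. Going by the values given here, that single step stays within the scatter, and no measured compound carries dimethylamino here, so the expectation in this assay is no step beyond the scatter, with a wide range. The expected step is a 1.6-fold higher number from compound 3 to compound 4 (0.19 log units; within the scatter). For compound 4 the estimated value is 450 nM, with an expected range of 150 nM to 1300 nM.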

Compound 4, half-maximal inhibitory concentration: 230 nM
For compound 4 the middle estimate is 2.0-fold (0.29 log units) above the measured one; low and high end bracket the measured number.
By their numbers in this assay, from the lowest: compounds 1, 4, 3 and 2 (each within the scatter of the next, the first and the last beyond it).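

In this assay this carbon carries dimethylamino as well as it carries fluoro: the change gives a 1.3-fold lower number from compound 3 to compound 4 (0.10 log units; within the scatter) and so stays level with the smaller group. Set against methoxy, the same group gives a 2.3-fold lower number from compound 2 to compound 4 (0.36 log units; beyond the scatter) and is the first change at this carbon to pass the scatter, though only modestly. Nothing measured here accounts for either step.

On these data alone, a free amine, a carboxylic acid or a longer chain on this carbon remains open. So does whether dimethylamino would match the fluoro of compound 1 on its own carbon.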